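The source may hold more compounds than are shown below. What is called first, only, known or untested is meant among the compounds shown, and "the series" means these compounds.

Measured so far in an assay on HEK293 cells for displacement of a labelled ligand from adenosine receptor A2b (Homo sapiens), read by radioligand binding, with a stated time of 30 min; a lower number here means a stronger inhibitor, a higher number a weaker inhibitor:
compound 1 `CCOC(=O)C1=C(C(F)(F)F)NC(=O)NC1c1ccsc1` gives 575 nM
compound 2 `CC1=C(C(=O)OC(C)C(F)(F)F)C(c2ccco2)NC(=O)N1` gives 61.5 nM; 303 nM (2 entries)
compound 3 `CC1=C(C(=O)OC(C)C(F)(F)F)C(c2ccoc2)NC(=O)N1` gives 234 nM

Among the two single numbers compound 3 holds the lower one; compound 1 sits above it by a gap beyond the usual scatter. Compound 2 carries no single number, its entries spread widely (the several entries of compound 2 in this assay, 61.5 nM; 303 nM (2 entries)), so no order can be set between compound 2 and compound 3. Compound 4 `CC1=C(C(=O)OC(C)C(F)(F)F)C(c2ccsc2)NC(=O)N1` differs from compound 3 in one place: thiophen-3-yl in place of furan-3-yl on a saturated ring carbon. Among the compounds with values here, no measured pair isolates this change, since compound 1 differs from compound 3 in more than that one place. The step from compound 3 to compound 4 in this assay is expected to be a 1.2-fold lower number from compound 3 to compound 4 (0.07 log units; within the scatter), none beyond the scatter. Compound 4 is estimated at 200 nM, with a range of 70 nM to 600 nM.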

Compound 4, inhibition constant: 643 nM
Beside the measured number, compound 4's estimate is 3.2-fold (0.51 log units) below it; measured number outside the range, above it.
By their numbers in this assay, from the lowest: compound 3; then compounds 1 and 4 (each within the scatter of the next).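

On a saturated ring carbon of the shared core, thiophen-3-yl in place of furan-3-yl is not a neutral exchange in this assay: the step is a 2.7-fold higher number from compound 3 to compound 4 (0.44 log units; beyond the scatter). This is the only pair shown that isolates a single change at this position, and it shows that swapping the ring oxygen for sulfur alone, with the heavy-atom count unchanged, moves the number. The step is modest, so this position responds to the hetero atom without a large swing.

Compound 2 still cannot be placed against compound 3 or compound 4: the several entries of compound 2 in this assay, 61.5 nM; 303 nM (2 entries). From the compounds shown here alone, whether a phenyl or pyridin-3-yl ring at this position would follow the same direction stays open.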